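A few compounds are considered here, and "the series" means these few. Any claim that something is new, unique, unknown or untested is made for them only; others in the source may bear on it.

Measured compounds in the series:
- compound 1 `NC1=NC2(CCSCC2)N(OCCCOc2ccc(Cl)c(Cl)c2)C(N)=N1`: 89.8%
- compound 2 `NC1=NC2(CCOCC2)N(OCCCOc2ccc(Cl)cc2Cl)C(N)=N1`: "not determined" (no result reported)
- compound 3 `NC1=NC2(CCOCC2)N(OCCCOc2ccc(Cl)c(Cl)c2)C(N)=N1`: "not determined" (no result reported)

Working notes. In an assay on isolated protein for inhibition of Dihydrofolate reductase (Homo sapiens), read by spectrophotometry, using NADPH, with stated times of 5 s and 6 min, tested at 50 uM (a higher number here means a stronger effect of the compound at the concentration tested, a lower number a weaker effect), compound 1 gives 89.8%. Among the compounds with values here, for compound 2 and compound 3 no result in this assay is available, so compound 1 holds the only number in the set and no step between two measured compounds can be computed; there is nothing to calibrate against beyond this single reading.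

Compound 4 `NC1=NC2(CCSCC2)N(OCCCOc2ccccc2Cl)C(N)=N1` is the next compound to be measured in this assay. It differs from compound 1 in one place: 2-chlorophenyl in place of 3,4-dichlorophenyl on an oxygen on a saturated carbon. With only one measured point, the size of this step is uncertain. The working expectation is that the step from compound 1 to compound 4 in this assay stays small or goes somewhat downward, and the estimated change is a number 11.8 percentage points lower from compound 1 to compound 4 (beyond the scatter). Compound 4 is accordingly expected to give about 78% in this assay, with a range from 50% to 95%, a wide band because compound 1 at 89.8% is the only anchor.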

Compound 4, a percentage reported as inhibition, at one concentration (the size of the read-out at that concentration, not a potency): 89.6%
The estimate for compound 4 lay 11.6 percentage points below the measured number; the range from low to high includes it.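

The step at this position is a number 0.2 percentage points lower from compound 1 to compound 4 (within the scatter) in this assay, so 2-chlorophenyl in place of 3,4-dichlorophenyl on an oxygen on a saturated carbon leaves the read-out unchanged, even with one chlorine fewer. Within the data shown here, this is the first readable step, and for this pair it shows that the read-out does not depend on keeping both chlorines of 3,4-dichlorophenyl. No measurement shown here accounts for this outcome.

From the compounds shown here alone, the read-out is taken at one concentration and is not a potency, so any difference in potency between compound 1 and compound 4 remains open. Also open, going by these compounds, is how the position responds to a plain phenyl, or to a phenyl carrying an amine or a carboxylic acid, and steps involving the cores of compound 2 and compound 3 cannot be read.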